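A few compounds are considered here, and "the series" means these few. Any claim that something is new, unique, unknown or untested is made for them only; others in the source may bear on it.

Within the data shown here, in a functional assay on L1210 cells (Mus musculus) for antiproliferative activity, with a stated time of 48 h (a higher number here means a weaker inhibitor, a lower number a stronger inhibitor), compound 2 `Nc1ccc(/C=C/C(=O)c2ccccc2)cc1` gives 88000 nM as the higher of the two numbers so far, against compound 1 `C=C(Br)C(=O)Nc1ccc(/C=C/C(=O)c2ccccc2)cc1` at 5000 nM in the same test. Among the measured compounds shown here, the only measured step of an 18-fold higher number from compound 1 to compound 2 (1.25 log units; beyond the scatter) is large, but it swaps (1-bromoethenyl)carbonyl for hydrogen on a nitrogen. The change to compound 3 `Nc1ccc(/C=C/C(=O)c2ccc(I)cc2)cc1` is iodo in place of hydrogen on an aromatic carbon on an aromatic carbon, para to a large group. The measured step gives no size for this change, so no step beyond the scatter is expected in this assay on present data. The expected step of a 1.5-fold lower number from compound 2 to compound 3 (0.17 log units; within the scatter) is therefore small. Compound 3 is estimated at 60000 nM with an expected range from 15000 nM to 150000 nM for now.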

Compound 3, half-maximal inhibitory concentration: 50000 nM
The estimate for compound 3 lay 1.2-fold (0.08 log units) above the measured number, and the stated range covers the measured number.
By their numbers in this assay, from the lowest: compound 1; then compounds 3 and 2 (each within the scatter of the next).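

In this assay, among these compounds, iodo in place of hydrogen on an aromatic carbon, para to a large group, gives a 1.8-fold lower number from compound 2 to compound 3 (0.25 log units; within the scatter) and so adds a first reading at this position. A single iodine atom can stand here without a step beyond the scatter, unlike the large step seen on the nitrogen. Nothing measured on these compounds speaks to the reason for this result.

As far as these compounds go, whether the same position accepts a methoxy group, a carboxylic acid or an amine stays open. Also open, from the compounds shown here alone, is whether iodo gives a similar step when (1-bromoethenyl)carbonyl sits on the nitrogen.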